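Replacing the ethyl on the nitrogen of compound 3

The source may report more compounds than this note shows. Statements on the series, on what has been measured and on what is new or still open speak of the compounds shown alone.

Compound 1 `N#Cc1c(Cl)nc(SCc2nc3ccccc3[nH]2)nc1-c1ccccc1`: 8.62 nM
Compound 2 `N#Cc1c(NN)nc(SCc2nc3ccccc3[nH]2)nc1-c1ccccc1`: 2.68 nM
Compound 3 `CCNc1nc(SCc2nc3ccccc3[nH]2)nc(-c2ccccc2)c1C#N`: 3.96 nM

In a functional assay on GOTO cells (Homo sapiens) for cytotoxicity, read by MTT assay, with a stated time of 3 days (on this read-out higher numbers stand for weaker inhibition and lower numbers for stronger inhibition), compound 3 gives 3.96 nM. This lies within the scatter of compound 2 at 2.68 nM and clearly under compound 1 at 8.62 nM, the highest number of the three.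

The next compound, compound 4 `N#Cc1c(NC(N)=S)nc(SCc2nc3ccccc3[nH]2)nc1-c1ccccc1`, keeps the shared core but loses the ethyl on a nitrogen on an aromatic ring: a group of 3 heavy atoms (1 carbon, 1 nitrogen, 1 sulfur; no ring) in place of a group of 2 heavy atoms (2 carbon; no ring), on a nitrogen on an aromatic ring.

Going by the values given here, three measured steps bear on this change. Two of them replace chloro on an aromatic carbon, and both are modest: a 3.2-fold lower number from compound 1 to compound 2 (0.51 log units; beyond the scatter) and a 2.2-fold lower number from compound 1 to compound 3 (0.34 log units; beyond the scatter). The closest guide is the change made on the same nitrogen, a 1.5-fold higher number from compound 2 to compound 3 (0.17 log units; within the scatter), which stays within the scatter. So far, then, the two groups carried on that nitrogen give numbers that cannot be told apart. However, no measured compound carries the group entering here, so this comparison is only a loose guide.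

In this assay no step beyond the scatter is therefore expected, and the estimated change is a 1.1-fold higher number from compound 3 to compound 4 (0.06 log units; within the scatter). For compound 4 the expected value is 4.5 nM, with an estimated range of 1.5 nM to 13 nM.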

Compound 4, half-maximal inhibitory concentration: 4.8 nM
Beside the measured number, compound 4's estimate is 1.1-fold (0.03 log units) below it, within the range that was stated.
By their numbers in this assay, from the lowest: compounds 2, 3, 4 and 1 (each within the scatter of the next, the first and the last beyond it).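

In this assay, the group of 3 heavy atoms (1 carbon, 1 nitrogen, 1 sulfur; no ring) on a nitrogen on an aromatic ring cannot be told apart from the ethyl, a 1.2-fold higher number from compound 3 to compound 4 (0.08 log units; within the scatter), or from the amino, a 1.8-fold higher number from compound 2 to compound 4 (0.25 log units; within the scatter), so three different groups on that nitrogen now give numbers within the scatter of their neighbours, even though this one adds a double bond, a hydrogen-bond donor and a hydrogen-bond acceptor that the ethyl lacks. Going by these compounds alone, what the earlier compounds did not show is that replacing chloro on an aromatic carbon need not take the number beyond the scatter: a 1.8-fold lower number from compound 1 to compound 4 (0.25 log units; within the scatter) stays within it, whereas a 3.2-fold lower number from compound 1 to compound 2 (0.51 log units; beyond the scatter) and a 2.2-fold lower number from compound 1 to compound 3 (0.34 log units; beyond the scatter) lie beyond it. No measurement offered here accounts for how closely these groups read alike.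

The compounds shown leave open whether this flat picture would hold for a longer chain such as butyl or for a ring such as morpholine on the same nitrogen. They also leave open how a carboxylic acid or a methoxy group would read on that aromatic carbon in place of chloro.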